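Selenocyanate carbamates: shortening the ester chain

The compounds below may be only part of what the source reports. "The series", "measured", "known", "first", "only" and "open" are said of these compounds alone.

Measured compounds:
- compound 1, `CC(C)COC(=O)Nc1ccc([Se]C#N)cc1`: 31300 nM
- compound 2, `C=CCOC(=O)Nc1ccc([Se]C#N)cc1`: 48600 nM

Both compounds share a core carrying a selenocyanate group and a carbamate, and differ only in the chain on the carbamate oxygen. Among the compounds with values here, in a functional assay on HT-29 cells (Homo sapiens) for cytotoxicity, read by MTT assay, with a stated time of 72 h (on this read-out higher numbers stand for weaker inhibition of growth and lower numbers for stronger inhibition of growth), compound 2 gives 48600 nM, the higher of the two measured numbers, while its only neighbour compound 1 gives 31300 nM; the step of a 1.6-fold higher number from compound 1 to compound 2 (0.19 log units; within the scatter) stays within the scatter, so the two cannot be ranked.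

Compound 3, `CCOC(=O)Nc1ccc([Se]C#N)cc1`, has not yet been measured. It differs from compound 2 by methyl in place of vinyl on a saturated chain carbon bound to an oxygen next to a carbonyl group. Within the data shown here, the one measured step, a 1.6-fold higher number from compound 1 to compound 2 (0.19 log units; within the scatter), changed the ester chain at the same place and moved the number only within the scatter, so a change of similar size is expected here: the estimated step is a 1.2-fold lower number from compound 2 to compound 3 (0.08 log units; within the scatter), with no direction beyond the scatter. Compound 3 is therefore expected to give about 40000 nM, likely between 18000 nM and 90000 nM.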

Compound 3, concentration for total growth inhibition: 38000 nM
Compound 3: the middle estimate sits 1.1-fold (0.02 log units) above what was measured; the measured number falls inside the stated range.
By their numbers in this assay, from the lowest: compounds 1, 3 and 2 (each within the scatter of the next).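

In this assay, methyl in place of vinyl on a saturated chain carbon bound to an oxygen next to a carbonyl group stays within the scatter (a 1.3-fold lower number from compound 2 to compound 3 (0.11 log units; within the scatter)), and so does methyl in place of isopropyl at the same place (a 1.2-fold higher number from compound 1 to compound 3 (0.08 log units; within the scatter)). The third compound thus shows that this position gives the same picture for a second kind of change: neither removing the double bond of the allyl chain nor removing the isopropyl end separates the compounds, and all three remain unranked. No supporting measurement bears on why these numbers stay together.

From the compounds shown here alone, whether any group at this place can move the number beyond the scatter remains open. A much longer chain, a phenyl ring or an amine there would test that, in either direction.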